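This account rests on a few compounds, and the source may have more. Where it says the series, first, only, none or still open, it means among the compounds named here.

Compound 2 `COCCCCCCCCCCCCCCC/C=C1\CC(CO)(COC(=O)C(C)(C)C)OC1=O` is the strongest of the three measured compounds in a functional assay on MOLT-4F cells (Homo sapiens) for antiproliferative activity (on this read-out higher numbers stand for weaker inhibition of growth and lower numbers for stronger inhibition of growth), where compound 2 gives 0.498 ug/mL. Compound 1 `CC(C)(C)C(=O)OCC1(CO)C/C(=C\CCCCCCCCCCCO)C(=O)O1` gives 1.34 ug/mL in this assay, and compound 3 `CC(C)(C)C(=O)OCC1(CO)C/C(=C/CCCCCCCCCCCCCCC=O)C(=O)O1` gives 2.02 ug/mL. Among the measured compounds shown here, the only measured step that changes just one part of the structure is a 2.7-fold lower number from compound 1 to compound 2 (0.43 log units; beyond the scatter), and it alters the far end of the long chain, as does the step now considered. Compound 4 `CC(=O)OCCCCCCCCCCCCCCC/C=C1\CC(CO)(COC(=O)C(C)(C)C)OC1=O` differs from compound 2 by acetyl in place of methyl on an oxygen on a saturated carbon. The measured step gave a modest gain, while compound 3, with an aldehyde at the chain end, gives a higher number than compound 2. Taken together, these point to a small change in either direction, so compound 4 is expected to show a 1.2-fold higher number from compound 2 to compound 4 (0.08 log units; within the scatter), giving an estimated 0.6 ug/mL, between 0.25 ug/mL and 1.5 ug/mL.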

Compound 4, concentration for 50% growth inhibition: 1.55 ug/mL
For compound 4 the middle estimate is 2.6-fold (0.41 log units) below the measured one; measured number above the stated range.
By their numbers in this assay, from the lowest: compound 2; then compounds 1, 4 and 3 (each within the scatter of the next).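

At the far end of the long chain, putting acetyl in place of methyl on the oxygen is not a neutral swap in this assay, with a 3.1-fold higher number from compound 2 to compound 4 (0.49 log units; beyond the scatter) for this change. The acetoxy ending of compound 4 cannot be told apart from the hydroxy ending of compound 1, with a 1.2-fold higher number from compound 1 to compound 4 (0.06 log units; within the scatter) for that pair, so only the methoxy ending of compound 2 stands out among these three. No measurement here explains this difference.

From the compounds shown here alone, whether an amine or a carboxylic acid at the same chain end would give a number as low as compound 2 remains open.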